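From a Quinoline Amide to a Benzofuran Amide

The source may hold more compounds than are shown below. What is called first, only, known or untested is meant among the compounds shown, and "the series" means these compounds.

Of the compounds shown here, three built on one shared core have been tested in a functional assay on MCF7 cells (Homo sapiens) for cytotoxicity, read by MTT assay, with a stated time of 72 h; a lower number here means a stronger inhibitor, a higher number a weaker inhibitor. Compound 1 `CN1[C@@H]2c3[nH]c4ccccc4c3C[C@H]1[C@H](C#N)N1[C@@H](CN3C(=O)c4ccccc4C3=O)c3[nH]c4ccccc4c3C[C@@H]21` gives 610 nM. Compound 2 `CN1[C@@H]2c3[nH]c4ccccc4c3C[C@H]1[C@H](C#N)N1[C@@H](CNC(=O)c3cccc4c3CCCC4)c3[nH]c4ccccc4c3C[C@@H]21` gives 4470 nM, while compound 3 `CN1[C@@H]2c3[nH]c4ccccc4c3C[C@H]1[C@H](C#N)N1[C@@H](CNC(=O)c3ccc4ccccc4n3)c3[nH]c4ccccc4c3C[C@@H]21` gives 150 nM, the lowest of the three numbers and clearly separated from both others. Going by the values given here, the only single-point step among the measured compounds is a 30-fold lower number from compound 2 to compound 3 (1.47 log units; beyond the scatter), where quinolin-2-yl took the place of 1,2,3,4-tetrahydronaphthalen-5-yl on the carbonyl carbon.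

Compound 4 `CN1[C@@H]2c3[nH]c4ccccc4c3C[C@H]1[C@H](C#N)N1[C@@H](CNC(=O)c3cc4ccccc4o3)c3[nH]c4ccccc4c3C[C@@H]21` has not yet been measured. It differs from compound 3 in one place: 1-benzofuran-2-yl in place of quinolin-2-yl on a carbonyl carbon. Among the compounds with values here, the single step that bears on this position, a 30-fold lower number from compound 2 to compound 3 (1.47 log units; beyond the scatter), shows that the carbonyl substituent can shift the number strongly. Here, however, one aromatic bicycle carrying one hetero atom replaces another of similar size, so a smaller step is expected, a 2.0-fold higher number from compound 3 to compound 4 (0.30 log units; within the scatter), in the direction of a slightly weaker inhibitor. Compound 4 is accordingly estimated at 300 nM, with a range from 100 nM to 1000 nM.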

Compound 4, half-maximal inhibitory concentration: 320 nM
Compound 4: the middle estimate sits 1.1-fold (0.03 log units) below what was measured; measured number inside the range.
By their numbers in this assay, from the lowest: compound 3; then compounds 4 and 1 (each within the scatter of the next); then compound 2.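

In this assay, the result shows that the gain at this carbonyl carbon does not belong to quinolin-2-yl alone. 1-Benzofuran-2-yl retains most of it, with a 14-fold lower number from compound 2 to compound 4 (1.15 log units; beyond the scatter), and exchanging one bicycle for the other has only a modest cost, with a 2.1-fold higher number from compound 3 to compound 4 (0.33 log units; beyond the scatter), even though the ring nitrogen gives way to a ring oxygen and the six-membered ring to a five-membered one. The amide of compound 4 also cannot be told apart from the different group on compound 1, with a 1.9-fold lower number from compound 1 to compound 4 (0.28 log units; within the scatter).

What the compounds shown leave open is how naphthalen-2-yl, which has no hetero atom, or a single phenyl ring would read on this carbonyl carbon. Nothing measured here accounts for the differences among these amides.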